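A Benzyl Group on the Sulfur: Expected Half-Life

A few compounds are considered here, and "the series" means these few. Any claim that something is new, unique, unknown or untested is made for them only; others in the source may bear on it.

Of the compounds shown here, two have been measured in a physicochemical assay for pharmacokinetics, read by HPLC, in phosphate buffer, at pH 8.0; on this read-out higher numbers stand for a longer-lived compound and lower numbers for a shorter-lived compound. Compound 1 `CCSS/C(CCOC(=O)[C@@H](C)c1ccc2cc(OC)ccc2c1)=C(/C)N(C=O)CC(=O)OC[C@H]1O[C@H](O)[C@H](O)[C@@H](O)[C@@H]1O` gives 25 h, and compound 2 `COc1ccc2cc([C@H](C)C(=O)OCC/C(SSC(C)C)=C(\C)N(C=O)CC(=O)OC[C@H]3O[C@H](O)[C@H](O)[C@@H](O)[C@@H]3O)ccc2c1` gives 28.6 h. Compound 2 holds the higher of the two numbers, but its nearest neighbour is compound 1 at a 1.1-fold higher number from compound 1 to compound 2 (0.06 log units; within the scatter), so the two values cannot be told apart.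

Compound 3 `COc1ccc2cc([C@H](C)C(=O)OCC/C(SSCc3ccccc3)=C(\C)N(C=O)CC(=O)OC[C@H]3O[C@H](O)[C@H](O)[C@@H](O)[C@@H]3O)ccc2c1` has not yet been measured in this assay. It differs from compound 2 by benzyl in place of isopropyl on a sulfur. Among the compounds with values here, the only measured step that touches the same part of the molecule is the one from compound 1 to compound 2, where the chain carbon bound to the sulfur was altered and the outcome was a 1.1-fold higher number from compound 1 to compound 2 (0.06 log units; within the scatter), within the scatter. On that basis he expects no shift beyond the scatter for the change to benzyl, and the step from compound 2 to compound 3 is estimated as a 1.0-fold lower number from compound 2 to compound 3 (0.01 log units; within the scatter). For compound 3 the half-life in this assay is therefore estimated at 28 h, with a range from 15 h to 52 h.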

Compound 3, half-life: 19.5 h
For compound 3 the middle estimate is 1.4-fold (0.16 log units) above the measured one; the measured number falls inside the stated range.
By their numbers in this assay, from the lowest: compounds 3, 1 and 2 (each within the scatter of the next).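

In this assay, the step from the branched isopropyl to benzyl, which brings the first aromatic ring to the sulfur whose other neighbour is sulfur and raises the group from 3 to 7 heavy atoms, gives a 1.5-fold lower number from compound 2 to compound 3 (0.17 log units; within the scatter). Read as phenyl in place of methyl on a saturated chain carbon bound to a sulfur, the same place gives a 1.3-fold lower number from compound 1 to compound 3 (0.11 log units; within the scatter), so the half-life has now been seen to stay within the scatter across a change in size and from a purely aliphatic group to one bearing a ring, which the earlier pair of small alkyl groups could not show. Nothing at hand bears on the reason for these small steps, and the slight differences among the values should not be read as a trend.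

As far as these compounds go, it remains open whether a group of another kind on this sulfur, such as an amine, a carboxylic acid or a longer alkyl chain, would take the half-life beyond the scatter. From the compounds shown here alone, it is equally open whether a fluorine or a methoxy group on the phenyl ring of the benzyl would change the number at all.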